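A few compounds are considered here, and "the series" means these few. Any claim that something is new, unique, unknown or untested is made for them only; others in the source may bear on it.

Of the compounds shown here, three sharing one core have been measured in a physicochemical assay for solubility, at pH 7.4; on this read-out lower numbers stand for lower solubility and higher numbers for higher solubility. Compound 1 `NS(=O)(=O)c1ccc(S(=O)(=O)CCCO)c([N+](=O)[O-])c1` gives 800 ug/mL, compound 2 `NS(=O)(=O)c1ccc(S(=O)(=O)CCCO)c(C(=O)O)c1` gives 53000 ug/mL, and compound 3 `COC(=O)c1cc(S(N)(=O)=O)ccc1SCCCO` gives 1300 ug/mL. Compound 3 therefore lies within the scatter of compound 1, and both stand far below compound 2, the highest of the three.

The next compound is compound 4 `COC(=O)c1cc(S(N)(=O)=O)ccc1S(=O)(=O)CCCO`, which has not yet been measured in this assay. It differs from compound 3 in one place: (3-hydroxypropyl)sulfonyl in place of (3-hydroxypropyl)sulfanyl on an aromatic carbon. The only measured step among these compounds, a 66-fold higher number from compound 1 to compound 2 (1.82 log units; beyond the scatter), is large, but it is a different exchange, carboxy in place of nitro, and it leaves the (3-hydroxypropyl)sulfonyl group untouched. For the measured compounds named here, no measured pair shows (3-hydroxypropyl)sulfonyl in place of (3-hydroxypropyl)sulfanyl, so that large step offers no direct guide here. The nearest evidence is that compound 3 falls within the scatter of compound 1, which already carries the (3-hydroxypropyl)sulfonyl group and gives 800 ug/mL. No step beyond the scatter is therefore expected, and the estimated change is a 1.2-fold higher number from compound 3 to compound 4 (0.06 log units; within the scatter). The expected value for compound 4 is 1500 ug/mL, with an estimated range from 500 ug/mL to 5000 ug/mL.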

Compound 4, solubility: 14000 ug/mL
Compound 4: the middle estimate sits 9.3-fold (0.97 log units) below what was measured, and the stated range ends below it.
By their numbers in this assay, from the lowest: compounds 1 and 3 (each within the scatter of the next); then compound 4; then compound 2.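

In this assay, for the compounds shown here, the aromatic carbon ortho to a methoxycarbonyl group and para to a sulfamoyl group proves sensitive to the change at that sulfur-bearing substituent: (3-hydroxypropyl)sulfonyl in place of (3-hydroxypropyl)sulfanyl gives an 11-fold higher number from compound 3 to compound 4 (1.03 log units; beyond the scatter), a large step that no earlier pair could show. Going by these compounds alone, with the (3-hydroxypropyl)sulfonyl group held constant, the result also places methoxycarbonyl for the first time, with methoxycarbonyl in place of nitro giving an 18-fold higher number from compound 1 to compound 4 (1.24 log units; beyond the scatter), while methyl in place of hydrogen on the carboxy oxygen gives the modest step of a 3.8-fold lower number from compound 2 to compound 4 (0.58 log units; beyond the scatter), so that this series runs upward from nitro through methoxycarbonyl to carboxy. Nothing at hand accounts for the size of any of these steps.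

The compounds shown leave open whether the exchange of the sulfanyl chain for the sulfonyl chain would give a step of similar size with nitro or carboxy on the ring, as compound 3 and compound 4 are its only pair. Also open, as far as these compounds go, is how an amide in place of the methoxycarbonyl group, or a longer chain than the 3-hydroxypropyl one, would stand in this assay.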